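The source may report more compounds than this note shows. Statements on the series, on what has been measured and on what is new or still open speak of the compounds shown alone.

Measured in an ADME assay for permeability, using PAMPA, with a stated time of 30 min, at pH 7.4; a lower number here means that the compound crosses the layer more slowly, a higher number that the compound crosses the layer faster:
compound 1 `COc1ccc(F)cc1CNCCCNc1ccnc2cc(C3CCCCC3)ccc12` gives 23 10^-6 cm/s
compound 2 `COc1cccc(CNCCCNc2ccnc3cc(Oc4ccc(C(C)(C)C)cc4)ccc23)c1O` gives 317 10^-6 cm/s
compound 3 `c1coc(CNCCCNc2ccnc3cc(C4CCCCC4)ccc23)c1` gives 23 10^-6 cm/s

Compound 1 stands level with compound 3, the two together the lowest of the three numbers; compound 2 is the furthest from it, with a much higher number. Among the measured compounds shown here, the one measured step, no change at the digits printed from compound 1 to compound 3 (within the scatter), changes the group on a saturated chain carbon bound to an amine nitrogen, not the ring position altered here, so it does not bear on the step to compound 4 `COc1ccc(F)cc1CNCCCNc1ccnc2cc(-c3ccc(C(F)(F)F)cc3)ccc12`. The change is 4-(trifluoromethyl)phenyl in place of cyclohexyl on an aromatic carbon. For the measured compounds named here, compound 2 differs from compound 1 in more than one place, so no step is given for that pair; only its higher number is noted. Going by the values given here, with no directly relevant step, a rise of modest size is expected, a 1.7-fold higher number from compound 1 to compound 4 (0.24 log units; within the scatter). Compound 4 is estimated at 40 10^-6 cm/s, in the range 12 10^-6 cm/s to 130 10^-6 cm/s.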

Compound 4, apparent permeability: 237 10^-6 cm/s
Beside the measured number, compound 4's estimate is 5.9-fold (0.77 log units) below it; measured number outside the range, above it.
By their numbers in this assay, from the lowest: compounds 1 and 3 (each within the scatter of the next); then compounds 4 and 2 (each within the scatter of the next).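

In this assay, the aromatic carbon bearing cyclohexyl in compound 1 responds strongly to substitution: 4-(trifluoromethyl)phenyl in its place gives a 10-fold higher number from compound 1 to compound 4 (1.01 log units; beyond the scatter). The change on the saturated chain carbon gave no change at the digits printed from compound 1 to compound 3 (within the scatter), so this is the only large single-place step shown. No measurement at hand accounts for its size. Open, from the compounds shown here alone, is whether the rise follows the aromatic ring or the trifluoromethyl group, which an unsubstituted phenyl at this carbon would separate. Also open, going by these compounds, is whether the step holds with furan-2-yl on the chain.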